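From 2-bromobenzyl to 4-bromobenzyl on a shared core

This account rests on a few compounds, and the source may have more. Where it says the series, first, only, none or still open, it means among the compounds named here.

Of the compounds shown here, three with a shared core have so far been measured in a functional assay on HeLa cells (Homo sapiens) for antiproliferative activity, read by MTT assay, with a stated time of 48 h (a higher number here means a weaker inhibitor, a lower number a stronger inhibitor), to date. Compound 1 (`O=[N+]([O-])c1cccc(CSc2nnc(-c3ccc4c(c3)OCCO4)o2)c1`) gives 35600 nM there, compound 2 (`Fc1ccccc1CSc1nnc(-c2ccc3c(c2)OCCO3)o1`) gives 41600 nM and compound 3 (`Brc1ccccc1CSc1nnc(-c2ccc3c(c2)OCCO3)o1`) gives 22400 nM in the same test. Compound 3 thus stands within the scatter of both other compounds, and these numbers do not rank the three.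

Compound 4 (`Brc1ccc(CSc2nnc(-c3ccc4c(c3)OCCO4)o2)cc1`) has yet to be measured. Set against compound 3, it has the same atoms joined differently: 4-bromophenyl in place of 2-bromophenyl on a saturated chain carbon bound to a sulfur. Among the measured compounds shown here, only one measured step bears on this, and only loosely: a 1.9-fold lower number from compound 2 to compound 3 (0.27 log units; within the scatter), with bromo in place of fluoro on an aromatic carbon. For the measured compounds named here, no measured pair differs only in where a group sits on the aromatic ring, so the data cannot test this kind of change directly. Resting on a 1.9-fold lower number from compound 2 to compound 3 (0.27 log units; within the scatter) and on compound 3 at 22400 nM as the starting point, no step beyond the scatter is expected in this assay in either direction. The expected step is a 1.1-fold higher number from compound 3 to compound 4 (0.05 log units; within the scatter) and no larger. For compound 4 the estimated value is 25000 nM, with an expected range from 10000 nM to 60000 nM as its bounds.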

Compound 4, half-maximal inhibitory concentration: 23600 nM
The estimate for compound 4 lay 1.1-fold (0.03 log units) above the measured number; measured number inside the range.
By their numbers in this assay, from the lowest: compounds 3, 4, 1 and 2 (each within the scatter of the next).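

Among the compounds shown here, the pair of compound 3 and compound 4 gives the first direct reading of 4-bromophenyl in place of 2-bromophenyl on a saturated chain carbon bound to a sulfur: in this assay the result is a 1.1-fold higher number from compound 3 to compound 4 (0.02 log units; within the scatter), so the two placements of the bromine are not told apart in this test. The comparison with the fluoro compound reads a 1.8-fold lower number from compound 2 to compound 4 (0.25 log units; within the scatter), and it joins a 1.9-fold lower number from compound 2 to compound 3 (0.27 log units; within the scatter) in leaving compound 2 unseparated from either bromo compound, whichever of the two bromophenyl groups is present. No other measurement shown here speaks to what lies behind these close numbers.

The compounds shown carry only fluoro, bromo or nitro on the benzyl ring, so it remains open how an amine, a carboxylic acid or a methoxy group would read there, or how a longer chain would read in place of the saturated chain carbon bound to a sulfur. From the compounds shown here alone, since all four compounds lie within the scatter of their neighbours in this assay, it also remains open whether any change to this part of the shared core can move the number beyond the scatter at all.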